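Spirocyclic sulfonamides: trifluoromethoxy to trifluoromethyl swaps

This account rests on a few compounds, and the source may have more. Where it says the series, first, only, none or still open, it means among the compounds named here.

Three compounds on one shared core have been run in a functional assay on MDA-MB-231 cells (Homo sapiens) for inhibition, read by sulforhodamine B assay, with a stated time of 74 h; on this read-out higher numbers stand for weaker inhibition and lower numbers for stronger inhibition. Compound 1 `O=C1C=CC2(C=C1)OCC(=O)N2S(=O)(=O)c1ccc(OC(F)(F)F)cc1` carries a trifluoromethoxy group; in this assay compound 1 returns only a limit, > 10000 nM. Compound 2 `O=C1C=CC2(C=C1)OCC(=O)N2S(=O)(=O)c1ccccc1OC(F)(F)F` is built from the same atoms joined differently; the difference between the two cores is not broken down here. In this assay compound 2 likewise returns only a limit, > 10000 nM. Compound 3 `O=C1C=CC2(C=C1)OCC(=O)N2S(=O)(=O)c1ccc(C(F)(F)F)cc1` carries trifluoromethyl instead, and in this assay compound 3 gives 2100 nM.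

Among the measured compounds shown here, the one measured change is trifluoromethyl in place of trifluoromethoxy on an aromatic carbon, and it produces an at least 4.7-fold lower number from compound 1 to compound 3 (0.67 log units; beyond the scatter). Because (the limit of > 10000 nM in this assay, at which 2 of the 3 values shown sit), the upper end of that step is open.

Compound 4 `O=C1C=CC2(C=C1)OCC(=O)N2S(=O)(=O)c1ccccc1C(F)(F)F` has not yet been measured. It stands to compound 2 as compound 3 stands to compound 1: trifluoromethyl in place of trifluoromethoxy on an aromatic carbon. This is the same kind of change, not the same, since the place differs: ortho to a large group in compound 4, para to a large group in compound 3. For the measured compounds named here, the only reading of this kind of change, an at least 4.7-fold lower number from compound 1 to compound 3 (0.67 log units; beyond the scatter), rests on a limit on one side, so its true size is uncertain. Compound 4 is expected to move in the same direction, though with less confidence than the measured step would suggest on its face. The expected step is an at least 2.0-fold lower number from compound 2 to compound 4 (0.30 log units; that floor lies within the scatter). Compound 4 is estimated at 5000 nM, with an expected range from 1500 nM to 15000 nM.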

Compound 4, half-maximal inhibitory concentration: > 10000 nM
Compound 4: only a limit was reported (the forecaster's own chance of this, stated with the estimate: 40%); at least 2.0-fold (0.30 log units) between middle value and limit.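

Compound 2 and compound 4 both return only limits in this assay, so no step between them can be read: the limit of > 10000 nM in this assay, at which 3 of the 4 values shown sit.

Still open, from the compounds shown here alone, is whether trifluoromethyl in place of trifluoromethoxy, when ortho to a large group, changes the number at all, and how the true values of compound 1, compound 2 and compound 4 compare.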